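Vinyl to hex-1-yn-1-yl: cytotoxicity notes on three compounds

The compounds below may be only part of what the source reports. "The series", "measured", "known", "first", "only" and "open" are said of these compounds alone.

The series is followed in an ADME assay on L1210/0 cells (Mus musculus) for cytotoxicity, with a stated time of 48 h; a higher number here means a weaker inhibitor, a lower number a stronger inhibitor. Within the data shown here, compound 1 `C=Cc1cn([C@H]2C[C@H](O)[C@@H](CO)O2)c(=O)[nH]c1=O` is the only compound of the three with a measured number: in this assay compound 1 gives 14200 nM. Compound 2 `OC[C@H]1CCC[C@@H]1n1cnc2c(Cl)ncnc21` reaches only a limit of the assay, > 200000 nM. Compound 3 `Nc1nc(Cl)c2ncn(COCCO)c2n1` likewise stops at a limit, > 200000 nM. So compound 1 stands alone as the one number among the values shown, the other two sitting at the limit of > 200000 nM in this assay, at which 2 of the 3 values shown sit.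

Compound 4 `CCCCC#Cc1cn([C@H]2C[C@H](O)[C@@H](CO)O2)c(=O)[nH]c1=O` has not been measured. It differs from compound 1 in one place: hex-1-yn-1-yl in place of vinyl on an aromatic carbon. Among the measured compounds shown here, no measured pair in the set changes a single group, so no measured step guides the size of this change. The vinyl and the hex-1-yn-1-yl both sit on the same aromatic carbon of the shared core, and the replacement adds four carbons in a chain.

The expected step of a 2.1-fold higher number from compound 1 to compound 4 (0.32 log units; beyond the scatter) is small, a modest weakening that may not exceed the scatter. Compound 4 is therefore expected near 30000 nM, with a range from 6000 nM to 150000 nM.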

Compound 4, half-maximal inhibitory concentration: > 200000 nM
Compound 4: a limit, no number (the forecaster's own chance of this, stated with the estimate: 15%); at least 6.6-fold (0.82 log units) between middle value and limit.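

Among these compounds, the first single-place change reads, in this assay, as an at least 14-fold higher number from compound 1 to compound 4 (1.14 log units; beyond the scatter). The group on this aromatic carbon can therefore, with nothing else altered on the shared core, decide whether a measured number is obtained at all: vinyl gives one, while hex-1-yn-1-yl does not. Compound 4 gives a limit and not a number, so the step has a lower bound only and no exact size: the limit of > 200000 nM in this assay, at which 3 of the 4 values shown sit.

The compounds shown do not separate the length of the chain from the change of double to triple bond; ethynyl or a butyl chain on the same aromatic carbon would bear on that. As far as these compounds go, it also stays open whether any group at this position gives a lower number than vinyl.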